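Series notes: acyl aryl variation and a hydrazone ring change

This account rests on a few compounds, and the source may have more. Where it says the series, first, only, none or still open, it means among the compounds named here.

Measured compounds:
- compound 1 `CN(C(=O)NC(=O)c1ccc([N+](=O)[O-])cc1)c1nc(C(F)(F)F)c(C(=O)N/N=C/c2cccc(C(F)(F)F)c2)s1` gives 1.67 ug/mL
- compound 2 `CN(C(=O)NC(=O)c1c(F)cccc1F)c1nc(C(F)(F)F)c(C(=O)N/N=C/c2cccc(C(F)(F)F)c2)s1` gives 25.9 ug/mL
- compound 3 `CN(C(=O)NC(=O)c1ccc(Cl)cc1Cl)c1nc(C(F)(F)F)c(C(=O)N/N=C/c2cccc(C(F)(F)F)c2)s1` gives 6.11 ug/mL

In a functional assay on BCG823 cells (Homo sapiens) for inhibition, read by MTT assay, with a stated time of 72 h (a lower number here means a stronger inhibitor, a higher number a weaker inhibitor), compound 3 stands second highest of the three numbers: a 3.7-fold higher number from compound 1 to compound 3 (0.56 log units; beyond the scatter) and a 4.2-fold lower number from compound 2 to compound 3 (0.63 log units; beyond the scatter). The third measured step, a 16-fold higher number from compound 1 to compound 2 (1.19 log units; beyond the scatter), likewise concerns the aryl on the carbonyl carbon. Within the data shown here, compound 4 `CN(C(=O)NC(=O)c1ccc(Cl)cc1Cl)c1nc(C(F)(F)F)c(C(=O)N/N=C/c2cc(C(F)(F)F)cc(C(F)(F)F)c2)s1` instead carries trifluoromethyl in place of hydrogen on an aromatic carbon on the hydrazone-side ring, which no measured pair varies. Among the measured compounds shown here, none of the measured steps bears on this change, so no step beyond the scatter is expected from compound 3 in this assay, and the estimated step is a 1.0-fold lower number from compound 3 to compound 4 (0.01 log units; within the scatter). Compound 4 is therefore expected near 6 ug/mL, between 2 ug/mL and 18 ug/mL.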

Compound 4, half-maximal inhibitory concentration: > 100 ug/mL
Compound 4: a limit, no number (the forecaster's own chance of this, stated with the estimate: 5%); middle value at least 16-fold (1.22 log units) from the limit.
By their numbers in this assay, from the lowest: compound 1; then compound 3; then compound 2. At a limit, above all of these: compound 4.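

The hydrazone-side ring proves sensitive to substitution: in this assay, trifluoromethyl in place of hydrogen on an aromatic carbon, meta to a trifluoromethyl group, gives an at least 16-fold higher number from compound 3 to compound 4 (1.21 log units; beyond the scatter). The earlier compounds shown here varied only the aryl on the carbonyl carbon, so they showed nothing of this position. The value for compound 4 is a limit, not a number: the limit of > 100 ug/mL in this assay, at which 1 of the 4 values shown sits.

Going by these compounds, it remains open whether any group on this carbon weakens inhibition or only trifluoromethyl does; a methyl or an amine there would separate the two. On these data alone, it also remains open whether the same change carries over to the 4-nitrophenyl compound 1.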